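The source may report more compounds than this note shows. Statements on the series, on what has been measured and on what is new or still open speak of the compounds shown alone.

Measured so far in a functional assay on KYSE-450 cells (Homo sapiens) for inhibition, read by MTT assay, with a stated time of 48 h; a higher number here means a weaker inhibitor, a lower number a stronger inhibitor:
compound 1 `C/C=C/C(=O)N(Cc1ccc(OC)c(C)c1)c1cc(OC)c(OC)c(OC)c1` gives 32900 nM
compound 2 `C=C(C)C(=O)N(Cc1ccc(OC)c(O)c1)c1cc(OC)c(OC)c(OC)c1` gives 200 nM
compound 3 `COc1ccc(CNc2cc(OC)c(OC)c(OC)c2)cc1[N+](=O)[O-]` gives 16800 nM

Compound 2 stands lowest of the three numbers in this assay. Its nearest neighbour is compound 3, and the gap to compound 3 lies beyond the scatter; the gap to compound 1 is wider still and also beyond the scatter. Compound 1 and compound 3 each differ from compound 2 in more than one place, so none of these pairs gives a clean step; only what the three values show is on record.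

The next compound, compound 4 `CC/C=C/C(=O)N(Cc1ccc(OC)c(O)c1)c1cc(OC)c(OC)c(OC)c1`, is reached from compound 2 by a single change: but-1-en-1-yl in place of 1-methylethenyl on a carbonyl carbon. The carbonyl carbon and the amide-type nitrogen it sits on are unchanged; the acyl side grows by one carbon and its double bond moves from a branched to a straight arrangement. Within the data shown here, no measured pair in this set shows what such a change alone does. Compound 1, which carries a different straight-chain acyl and a different aryl substituent, is weak, but it cannot be read as a step.

Expectation for compound 4: a modest loss of potency relative to compound 2, a step of a 3.0-fold higher number from compound 2 to compound 4 (0.48 log units; beyond the scatter) that may or may not exceed the scatter. The estimate for compound 4 is 600 nM, with a range from 150 nM to 3000 nM.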

Compound 4, half-maximal inhibitory concentration: 72 nM
Compound 4: middle estimate off by 8.3-fold (0.92 log units), on the high side; the whole stated range lies above it.
By their numbers in this assay, from the lowest: compound 4; then compound 2; then compounds 3 and 1 (each within the scatter of the next).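

In this assay, but-1-en-1-yl on the carbonyl carbon gives a stronger inhibitor than 1-methylethenyl, with a 2.8-fold lower number from compound 2 to compound 4 (0.44 log units; beyond the scatter), so a straight-chain acyl on this amide-type nitrogen is compatible with a nanomolar value on the core of compound 2. Among these compounds, compound 1 also carries a straight-chain acyl and gives 32900 nM, but it differs from compound 4 in more than one place, so its weak value cannot be read as an effect of that acyl, and no step can be drawn from it. No supporting measurement bears on why the step goes in this direction.

The extra carbon and the change from a branched to a straight arrangement of the double bond arrive together in this single step, so the compounds shown do not separate their contributions. Also open, from the compounds shown here alone, is how a saturated butyl chain or a longer hex-1-en-1-yl chain on the same carbonyl carbon would read in this assay, with the rest of compound 4 held fixed.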